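Adding a Benzoyl Group to a Weak Antiproliferative Lead

The source may report more compounds than this note shows. Statements on the series, on what has been measured and on what is new or still open speak of the compounds shown alone.

Compound 1 `O=C(Nc1ccc(-n2ccc3c(NC(=O)c4ccccc4)ncnc32)cc1)Nc1cccc(C(F)(F)F)c1`: 4500 nM
Compound 2 `Nc1ncnc2c1ccn2-c1ccc(NC(=O)Nc2cc(C(F)(F)F)cc(C(F)(F)F)c2)cc1`: 9500 nM

Both were tested in an ADME assay on HS27 cells (Homo sapiens) for antiproliferative activity, read by MTT assay, with a stated time of 24 h; a lower number here means a stronger inhibitor, a higher number a weaker inhibitor. Compound 2 stands at the higher of the two numbers, and its gap to compound 1 is beyond the usual scatter, so compound 2 is the weaker inhibitor here. Compound 3 `O=C(Nc1ccc(-n2ccc3c(NC(=O)c4ccccc4)ncnc32)cc1)Nc1cc(C(F)(F)F)cc(C(F)(F)F)c1` is not yet measured; it differs from compound 2 by benzoyl in place of hydrogen on a nitrogen on an aromatic ring. Compound 1 carries the same benzamido group and gives a lower number than compound 2, but it differs in a second place as well, so no single step can be read from it. The expected step from compound 2 to compound 3 is a 1.6-fold lower number from compound 2 to compound 3 (0.20 log units; within the scatter), a modest move toward a lower number. Compound 3 is therefore expected near 6000 nM, within 2500 nM to 15000 nM.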

Compound 3, half-maximal inhibitory concentration: > 10000 nM
Compound 3 ended at the assay's limit (the forecaster's own chance of this, stated with the estimate: 5%); middle value at least 1.6-fold (0.22 log units) from the limit.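

In this assay compound 3 gives > 10000 nM, which is a limit of the assay and not a number: the limit of > 10000 nM in this assay, at which 1 of the 3 values shown sits.

Benzoyl in place of hydrogen on this nitrogen therefore shows no move toward a lower number, with an at least 1.0-fold higher number from compound 2 to compound 3 (0.02 log units; that floor lies within the scatter). With benzamido present in both compounds, trifluoromethyl in place of hydrogen on an aromatic carbon gives an at least 2.2-fold higher number from compound 1 to compound 3 (0.34 log units; beyond the scatter), so the lower number of compound 1 goes with that one place.

Going by these compounds, the true size of both steps stays open, since compound 3 rests at a limit. On these data alone, whether a smaller acetyl group on this nitrogen would behave like benzoyl also stays open.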